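A Methyl on the Ring Nitrogen of Compound 3

The source may report more compounds than this note shows. Statements on the series, on what has been measured and on what is new or still open speak of the compounds shown alone.

In a functional assay on the whole organism with Mus musculus as the target (a lower number here means that less compound is needed, a higher number that more compound is needed for the effect), compound 1 `CCC(O)CNC(=O)/C=C/c1cccc(C(F)(F)F)c1` gives 64.4 mg/kg. In the same assay, compound 2 `CNC(=O)/C(C)=C/c1cccc(C(F)(F)F)c1` gives 68.8 mg/kg, and these two values lie within the usual scatter of each other. Compound 3 `O=C1CCC(O)(c2cccc(C(F)(F)F)c2)N1` is reported only as a limit, > 200 mg/kg. For the measured compounds named here, it is the one compound of the three without a number, and it stands at the limit of > 200 mg/kg in this assay, at which 1 of the 3 values shown sits.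

Compound 4 `CN1C(=O)CCC1(O)c1cccc(C(F)(F)F)c1` departs from compound 3 in a single place, with methyl in place of hydrogen on an amide-type nitrogen in a ring. Going by the values given here, no pair of measured compounds differs in only one place, so the data offer no direct precedent for this change. Compound 2 also carries a methyl on its amide nitrogen and gives 68.8 mg/kg, but its core differs from that of compound 3, so it is only a loose guide. In this assay, a small step is expected, with a modest shift towards lower doses at most and quite possibly none beyond the scatter. The estimated change is an at least 1.1-fold lower number from compound 3 to compound 4 (0.07 log units; that floor lies within the scatter). For compound 4 the expected value is 170 mg/kg, with an estimated range from 70 mg/kg to 400 mg/kg.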

Compound 4, dose for half-maximal effect: 51.6 mg/kg
Beside the measured number, compound 4's estimate is 3.3-fold (0.52 log units) above it, outside the stated range (below it).
By their numbers in this assay, from the lowest: compounds 4, 1 and 2 (each within the scatter of the next). At a limit, above all of these: compound 3.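

In this assay, for the compounds shown here, methyl in place of hydrogen on an amide-type nitrogen in a ring gives an at least 3.8-fold lower number from compound 3 to compound 4 (0.58 log units; beyond the scatter), the first change in one place that can be read. It shows that this nitrogen is a position where a single added carbon matters, and that a measured dose can be reached on the shared core with the hydroxy group and the trifluoromethyl-bearing aromatic group left as they are. The step is only a floor and its full size remains unknown, because compound 3 is reported as a limit and not as a number: the limit of > 200 mg/kg in this assay, at which 1 of the 4 values shown sits.

The compounds shown leave open whether a longer chain such as ethyl on the same ring nitrogen would move the dose further down, hold it or lose the effect, so the step describes methyl alone. They also leave open what the hydroxy group contributes once the methyl is in place, and whether a methoxy group or a plain hydrogen at that ring atom would keep the dose where compound 4 has it.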